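From isopropyl to sec-butyl on the aromatic nitrogen

A few compounds are considered here, and "the series" means these few. Any claim that something is new, unique, unknown or untested is made for them only; others in the source may bear on it.

Measured so far in an assay on HEK293 cells for activation of Kir3.1/Kir3.2 (Homo sapiens), read by thallium flux; a lower number here means a smaller maximal response, a higher number a larger maximal response:
compound 1, `Cc1cc(NC(=O)Cn2nnc(-c3ccccc3)n2)n(C2CCC(F)(F)CC2)n1`, gives 68%
compound 2, `Cc1cc(NC(=O)Cn2nnc(-c3ccccc3)n2)n(C2CCC(C)(C)CC2)n1`, gives > 19%, which is a limit of the assay and not a number
compound 3, `Cc1cc(NC(=O)Cn2nnc(-c3ccccc3)n2)n(C(C)C)n1`, gives 107%

Compound 3 stands highest of the two numbers shown. Its nearest neighbour is compound 1, and the step of a number 39 percentage points higher from compound 1 to compound 3 (beyond the scatter), where isopropyl replaces 4,4-difluorocyclohexyl on an aromatic nitrogen. Compound 2 sits at a limit, so the step that the limit leaves unreadable from compound 2 to compound 3 and the step that the limit leaves unreadable from compound 1 to compound 2 give no readable size.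

Compound 4, `CCC(C)n1nc(C)cc1NC(=O)Cn1nnc(-c2ccccc2)n1`, differs from compound 3 in one place: methyl in place of hydrogen on a saturated chain carbon, two bonds along the chain from an aromatic nitrogen. Going by the values given here, no measured step covers this exact change. Among the compounds with values here, the only readable step, from compound 1 to compound 3, favours the smaller isopropyl over a six-membered ring, and sec-butyl lies between those two in bulk. The step of a number 12 percentage points lower from compound 3 to compound 4 (beyond the scatter) is therefore expected to be small, likely within the scatter, with a modest lowering more probable than a rise. Compound 4 is expected to give 95% in this assay, within 65% to 120%.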

Compound 4, largest response reached (Emax), in percent of the reference or control that the assay uses: > 69%
Compound 4: only a limit was reported; the forecaster's own chance of this, stated with the estimate: 10%; the middle value lies beyond the limit too.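

In this assay compound 4 gives > 69%, which is a limit of the assay and not a number, so the extra methyl on the saturated chain carbon is compatible with a sizeable maximal response but does not fix its size. Replacing 4,4-difluorocyclohexyl with sec-butyl gives a number at least 1 percentage points higher from compound 1 to compound 4 (that floor lies within the scatter), so this floor alone does not establish a real rise over that ring. The steps to compound 4 from compound 3 and from compound 2 cannot be read, which leaves the effect of going from isopropyl to sec-butyl unsettled: the limit of > 69% in this assay, at which 1 of the 4 values shown sits.

The compounds shown leave open where the response of sec-butyl truly lies. They also leave open how tert-butyl, cyclopropyl or a longer chain such as n-pentyl on the aromatic nitrogen would read in this assay.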